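The compounds below may be only part of what the source reports. "The series", "measured", "known", "first", "only" and "open" are said of these compounds alone.

Three compounds were measured in an ADME assay on MT2 cells (Homo sapiens) for cytotoxicity; on this read-out higher numbers stand for lower toxicity in this test and lower numbers for higher toxicity in this test:

compound 1, `COc1ncnc(Nc2ccc(Cl)c(OCC=C(C)C)c2)n1`: 18000 nM
compound 2, `COc1nc(Nc2ccc(Cl)c(OCC=C(C)C)c2)nc(OC)n1`: 20000 nM
compound 3, `COc1ccnc(Nc2ccc(C#N)c(OCC=C(C)C)c2)n1`: 230 nM

Compound 2 differs from compound 1 by methoxy in place of hydrogen on an aromatic carbon, and in this assay this gave a 1.1-fold higher number from compound 1 to compound 2 (0.05 log units; within the scatter). Compound 3 stands lowest of the three numbers, beyond the scatter from compound 1 and compound 2 alike; how its core differs from the core of compound 1 is not broken down here.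

Compound 4, `COc1cc(OC)nc(Nc2ccc(C#N)c(OCC=C(C)C)c2)n1`, is not yet measured. It differs from compound 3 by methoxy in place of hydrogen on an aromatic carbon. This is the same kind of change as that from compound 1 to compound 2, but not the same: there the methoxy entered a six-membered aromatic ring with 3 nitrogen, between two ring nitrogen atoms, whereas here it enters a six-membered aromatic ring with 2 nitrogen, next to the ring nitrogen.

Within the data shown here, compound 4 is therefore expected to give a step of a 1.1-fold higher number from compound 3 to compound 4 (0.05 log units; within the scatter) in this assay, beside the earlier one, resting on the single measured step from compound 1 to compound 2. The estimate for compound 4 is 260 nM, with a range from 100 nM to 700 nM.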

Compound 4, half-maximal cytotoxic concentration: 810 nM
Estimate against measurement, compound 4: 3.1-fold (0.49 log units) below, and the stated range ends below it.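

In this assay, methoxy in place of hydrogen on an aromatic carbon did not carry over unchanged from one core to the other. On the core of compound 3 the change gave a 3.5-fold higher number from compound 3 to compound 4 (0.55 log units; beyond the scatter), and this step differs from the earlier one by more than the scatter of two such steps: the same change on two cores in this assay, a 1.1-fold higher number (0.05 log units; within the scatter) from compound 1 to compound 2 and a 3.5-fold higher number (0.55 log units; beyond the scatter) from compound 3 to compound 4, 3.2-fold (0.50 log units) apart, beyond the scatter of two such steps. This shows that the step measured on the core of compound 1 cannot simply be transferred to the core of compound 3, but with a single step on each core it does not show what sets the two apart, as those cores differ in more than one place.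

The compounds shown leave open whether the larger step goes with the ring that takes the methoxy or with the nitrile in place of the chlorine, as no pair here changes only one of these. They also leave open how an amine or a longer alkoxy chain in the same place would behave on either core.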